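Adding a Nitro Group to the Anilino Ring of Compound 3

The source may hold more compounds than are shown below. What is called first, only, known or untested is meant among the compounds shown, and "the series" means these compounds.

Measured so far:
In a functional assay, read by spectrophotometry, with a stated time of 5 min (on this read-out higher numbers stand for weaker inhibition and lower numbers for stronger inhibition), compound 1 `O=c1cc(/C=N\c2ccc(O)cc2)c2c(OCc3ccccc3)cc(OCc3ccccc3)cc2o1` gives 249000 nM.
In this assay compound 2 `Nc1ccccc1/N=C\c1cc(=O)oc2cc(OCc3ccccc3)cc(OCc3ccccc3)c12` gives 258000 nM.
In this assay compound 3 `O=c1cc(/C=N\Nc2ccccc2)c2c(OCc3ccccc3)cc(OCc3ccccc3)cc2o1` gives 303000 nM.

Compound 3 carries the highest of the three numbers, yet every step separating it from the others stays within the scatter: a 1.2-fold higher number from compound 1 to compound 3 (0.09 log units; within the scatter) and a 1.2-fold higher number from compound 2 to compound 3 (0.07 log units; within the scatter). The remaining pair behaves the same way, a 1.0-fold higher number from compound 1 to compound 2 (0.02 log units; within the scatter), so none of the three can be called the weakest or the strongest inhibitor on these data.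

Compound 4 `O=c1cc(/C=N\Nc2ccc([N+](=O)[O-])cc2)c2c(OCc3ccccc3)cc(OCc3ccccc3)cc2o1` differs from compound 3 in one place: nitro in place of hydrogen on an aromatic carbon. Going by the values given here, the three measured steps all exchange the group carried on the double-bonded nitrogen, and all three are within the scatter, which is the only guidance the set offers for a change at that end of the molecule. On that basis no step beyond the scatter is expected, a 1.0-fold lower number from compound 3 to compound 4 (0.00 log units; within the scatter), in either direction.

Compound 4 is therefore estimated at 300000 nM in this assay, with a range from 150000 nM to 600000 nM.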

Compound 4, half-maximal inhibitory concentration: 419000 nM
Compound 4: the middle estimate sits 1.4-fold (0.15 log units) below what was measured, within the range that was stated.
By their numbers in this assay, from the lowest: compounds 1, 2, 3 and 4 (each within the scatter of the next).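

In this assay, going by these compounds alone, the first change on the anilino ring itself, nitro in place of hydrogen on an aromatic carbon para to a large group, stays within the scatter (a 1.4-fold higher number from compound 3 to compound 4 (0.14 log units; within the scatter)). The set thus now reaches beyond exchanges of the whole group on the double-bonded nitrogen, and at this position of the ring the entry of a nitro group does not separate compound 4 from compound 3. The wider exchanges read the same way (a 1.6-fold higher number from compound 2 to compound 4 (0.21 log units; within the scatter); a 1.7-fold higher number from compound 1 to compound 4 (0.23 log units; within the scatter)), so (4-nitrophenyl)amino cannot be told apart from 2-aminophenyl or 4-hydroxyphenyl on these data, and nothing at hand gives a reason for this result.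

Going by these compounds, whether another group at this same place, such as an amine or a carboxylic acid, would give a step beyond the scatter remains open. On these data alone, all four compounds also share the benzyloxy groups on the core, so what a hydroxyl or a methoxy group there would do to the number remains open as well.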